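Second Methoxy Added: Expected Effect on Cytotoxicity

The source may report more compounds than this note shows. Statements on the series, on what has been measured and on what is new or still open speak of the compounds shown alone.

Going by the values given here, compound 2 `COc1ccc(/C=C/C(=O)NCCCC(C)Nc2cc(OC)cc3cccnc23)cc1` sits at the weak end of the numbers so far. In an ADME assay on L6 cells (Rattus norvegicus) for cytotoxicity, read by resazurin assay, with a stated time of 70 h (a lower number here means a stronger inhibitor, a higher number a weaker inhibitor), compound 2 gives only a limit, > 240000 nM. Compound 1 `COc1cc(NC(C)CCCNC(=O)/C=C/c2ccccc2)c2ncccc2c1` gives 18500 nM in this assay, so the step of an at least 12-fold higher number from compound 1 to compound 2 (1.11 log units; beyond the scatter) ran up to the limit (the limit of > 240000 nM in this assay, at which 1 of the 2 values shown sits). Compound 3 `COc1cc(NC(C)CCCNC(=O)/C=C/c2ccc(OC)c(OC)c2)c2ncccc2c1` differs from compound 2 by methoxy in place of hydrogen on an aromatic carbon. Among the compounds with values here, only the step from compound 1 to compound 2 bears on this change; it was large and ran toward weaker, so in this assay no step beyond the scatter is expected, with compound 3 staying at the limit a step that the limit leaves unreadable from compound 2 to compound 3. Compound 3 is therefore estimated at 250000 nM, between 90000 nM and 700000 nM.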

Compound 3, half-maximal inhibitory concentration: > 220000 nM
Compound 3 ended at the assay's limit; the forecaster's own chance of this, stated with the estimate: 75%; the middle value does not contradict the limit.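

Replacing phenyl with 3,4-dimethoxyphenyl gives an at least 11-fold higher number from compound 1 to compound 3 (1.07 log units; beyond the scatter) in this assay, so the weak end of the range holds for this group as well as for 4-methoxyphenyl. For compound 3, > 220000 nM is a limit of the assay, not a number. On these data alone, the step from compound 2 to compound 3 cannot be read, so whether the second methoxy adds anything to the first remains unknown. As far as these compounds go, whether an amine or a carboxylic acid in place of methoxy on this ring would bring the number back into the readable range stays open.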